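A New Aryl Group on the Amide-Type Nitrogen

The compounds below may be only part of what the source reports. "The series", "measured", "known", "first", "only" and "open" are said of these compounds alone.

Measured compounds:
compound 1, `O=C(Nc1ccc(Cl)cc1)Nc1ccc(Oc2ccc(-c3nccs3)cc2)cc1`: 17.7%
compound 2, `O=C(Nc1ccc(Oc2ccc(-c3nccs3)cc2)cc1)Nc1ccc(Cl)c([N+](=O)[O-])c1`: 77.1%

In a functional assay on A549 cells (Homo sapiens) for inhibition, read by MTT assay and WST assay, with a stated time of 72 h, tested at 10 uM (a lower number here means less inhibition of growth, a higher number more inhibition of growth at the concentration tested), compound 1 gives 17.7%, and compound 2 gives 77.1%. For the measured compounds named here, the one measured step is a number 59.4 percentage points higher from compound 1 to compound 2 (beyond the scatter), so compound 2 stands highest of the two numbers, with compound 1 the nearest and far lower. Compound 3, `O=C(Nc1ccc(Oc2ccc(-c3nccs3)cc2)cc1)Nc1cc(Br)cc(C(F)(F)F)c1`, differs from compound 2 by 3-bromo-5-(trifluoromethyl)phenyl in place of 4-chloro-3-nitrophenyl on an amide-type nitrogen. Going by the values given here, only the step of a number 59.4 percentage points higher from compound 1 to compound 2 (beyond the scatter) bears on this change: it shows that the nitro group, taken away in compound 3, went with a large rise in growth inhibition. Among the compounds with values here, the entering bromine and trifluoromethyl have no measured counterpart among the two compounds. A fall from compound 2 is therefore expected, of uncertain size, with wide bounds. Compound 3 is estimated to give 35%, within 10% to 65%, an expected step of a number 42.1 percentage points lower from compound 2 to compound 3 (beyond the scatter).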

Compound 3, percent growth inhibition at one concentration: 81.7%
Compound 3: middle estimate off by 46.7 percentage points, on the low side, outside the stated range (above it).
By their numbers in this assay, from the lowest: compound 1; then compounds 2 and 3 (each within the scatter of the next).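

In this assay the replacement of 4-chloro-3-nitrophenyl by 3-bromo-5-(trifluoromethyl)phenyl on the amide-type nitrogen gives a number 4.6 percentage points higher from compound 2 to compound 3 (within the scatter) and so leaves the reading unchanged. Set against the 4-chlorophenyl group, the same aryl group gives a number 64 percentage points higher from compound 1 to compound 3 (beyond the scatter) and brings the large rise seen with the nitro compound, so at this position high growth inhibition does not need a nitro group or a chlorine. Nothing available explains why these two different aryl groups read alike.

Still open, as far as these compounds go, is whether the bromine or the trifluoromethyl alone would be enough, as the two enter together in compound 3. Also open, from the compounds shown here alone, is how an aryl group carrying an amine or a carboxylic acid would read in this assay at this nitrogen.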